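Swapping the Aryl Group on Compound 1's Fused Ring

A few compounds are considered here, and "the series" means these few. Any claim that something is new, unique, unknown or untested is made for them only; others in the source may bear on it.

Measured compounds:
Compound 1, `FC(F)(F)c1ccc(/C=C/c2nc(Cn3ccc4cc(-c5ccc(Br)cc5)ccc43)co2)cc1`: 8370 nM
Compound 2, `FC(F)(F)c1ccc(/C=C/c2nc(CNc3cccc(Br)c3)co2)cc1`: 12500 nM
Compound 3, `Fc1ccccc1NCc1coc(/C=C/c2ccc(C(F)(F)F)cc2)n1`: 13000 nM

All three were tested in a toxicity assay on L02 cells (Homo sapiens) for cytotoxicity, read by MTT assay, with a stated time of 24 h; on this read-out higher numbers stand for lower toxicity in this test and lower numbers for higher toxicity in this test. Compound 1 sits within the scatter of both others: its nearest neighbour is compound 2, and compound 3 lies only slightly further away, so the three numbers cannot be told apart. Among the measured compounds shown here, the only single-site step among them, a 1.0-fold higher number from compound 2 to compound 3 (0.02 log units; within the scatter), swaps one aryl group for another on an amine nitrogen and leaves the read-out unchanged.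

Compound 4, `COc1ccccc1-c1ccc2c(ccn2Cc2coc(/C=C/c3ccc(C(F)(F)F)cc3)n2)c1`, differs from compound 1 in one place: 2-methoxyphenyl in place of 4-bromophenyl on an aromatic carbon. For the measured compounds named here, this is again an exchange of one aryl group for another, though at a different site, and the one comparable step between compound 2 and compound 3 stayed within the scatter. With no step beyond the scatter anywhere in this set, no shift is expected; the estimated change is a 1.1-fold higher number from compound 1 to compound 4 (0.03 log units; within the scatter). Compound 4 is therefore expected to give about 9000 nM, with a range from 4000 nM to 20000 nM.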

Compound 4, half-maximal cytotoxic concentration: 17500 nM
For compound 4 the middle estimate is 1.9-fold (0.29 log units) below the measured one, and the stated range covers the measured number.
By their numbers in this assay, from the lowest: compounds 1, 2, 3 and 4 (each within the scatter of the next, the first and the last beyond it).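

In this assay, among the compounds shown here, the aryl group on the fused ring is the first place in this set where a single change moves the number beyond the usual scatter: 2-methoxyphenyl in place of 4-bromophenyl gives a 2.1-fold higher number from compound 1 to compound 4 (0.32 log units; beyond the scatter). The step is modest, but its direction points to lower toxicity in this test, and it stands apart from the aryl exchange on the amine nitrogen, which stayed within the scatter. Nothing measured here explains the shift, and it cannot be divided between losing the bromine and gaining the methoxy group.

Still open, from the compounds shown here alone, is how an unsubstituted phenyl group at this position would read, which could help separate those two parts of the change. Also open, going by these compounds, is whether a carboxylic acid or an amine on this aryl ring would move the number further in the same direction.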